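This account rests on a few compounds, and the source may have more. Where it says the series, first, only, none or still open, it means among the compounds named here.

Compound 1, with the structure `CC(C)[C@@H](NC(=O)/C=C/c1ccncc1-c1ccc2ccccc2c1)C(=O)O`, is the starting point here. It is drawn as a propenamide carrying a pyridine bearing a naphthyl group, and its amide nitrogen holds an amino acid. In an assay on a protein complex for inhibition of CDK8/Cyclin C (Homo sapiens), with a stated time of 1 h (on this read-out lower numbers stand for stronger inhibition and higher numbers for weaker inhibition), compound 1 has the entry "not determined" (no result reported), so no single number stands for it, and it cannot be placed against the others on this read-out. Going by the values given here, of the remaining compounds, compound 2, with the structure `NC(=O)/C=C/c1ccncc1Br`, is the only one with a number: in this assay compound 2 gives 2420 nM. Compound 3, with the structure `NC(=O)/C=C/c1ccncc1Nc1ccc(F)cc1`, also has the entry "not determined" (no result reported) in this assay, so it too offers no number.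

The compound to be measured is compound 4, with the structure `CN(C)C(=O)/C=C/c1ccncc1-c1ccc2ccccc2c1`. The change from compound 1 to compound 4 is dimethylamino in place of (1-carboxy-2-methylpropyl)amino on a carbonyl carbon. Since no number for compound 1 exists in this assay, no size or direction of step between them can be computed, and any expectation has to lean on compound 2 alone, which shares only the propenamide on the pyridine core. Compound 4 is expected to land near that single reference, with a wide range to reflect how little is known, at an estimated 1500 nM, between 250 nM and 9000 nM.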

Compound 4, half-maximal inhibitory concentration: 30.1 nM
For compound 4 the middle estimate is 50-fold (1.70 log units) above the measured one; measured number outside the range, below it.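

In this assay, going by these compounds alone, compound 1 has the entry "not determined" (no result reported) while compound 4 gives 30.1 nM, so no step between the two can be read. The compounds shown leave open how much dimethylamino in place of (1-carboxy-2-methylpropyl)amino contributes to the value of compound 4. Nothing measured here offers an explanation for that value.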